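The source may hold more compounds than are shown below. What is called first, only, known or untested is meant among the compounds shown, and "the series" means these compounds.

Measured so far:
compound 1 `CCOC(=O)C1CCN(C(=O)c2cc(-c3ccc(C)cc3)nn2Cc2ccccc2)CC1` — 33.3%
compound 2 `Cc1ccc(-c2cc(C(=O)Oc3ccc(C(C)(C)C)cc3)n(Cc3ccccc3)n2)cc1` — 35%

In a functional assay on the whole organism (strain Swiss albino) for inhibition, with Mus musculus as the target, read by paw edema, with stated times of 30 min and 180 min, at a dose of 100 mg/kg by the subcutaneous route (on this read-out higher numbers stand for more inhibition at the one dose given (going by the name of the read-out) and lower numbers for less inhibition), compound 2 gives 35%, the higher of the two numbers, with compound 1 at 33.3% lying within the scatter of it, so the two stand level. Compound 3 `Cc1ccc(-c2cc(C(=O)Oc3ccc(-n4ccnc4)cc3)n(Cc3ccccc3)n2)cc1` is not yet measured; it differs from compound 2 by 1H-imidazol-1-yl in place of tert-butyl on an aromatic carbon. For the measured compounds named here, no measured pair isolates this change, so nothing sets its size. With two near-equal values across rather different structures, the step is expected to stay within the scatter; for compound 3 the estimate is 35% (range 22% to 48%), a step of no change at the digits printed from compound 2 to compound 3 (within the scatter).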

Compound 3, a percentage reported as inhibition, in the whole organism at one dose (the size of the read-out at that dose, not a potency): 15.4%
The estimate for compound 3 lay 19.6 percentage points above the measured number; the whole stated range lies above it.
By their numbers in this assay, from the lowest: compound 3; then compounds 1 and 2 (each within the scatter of the next).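

In this assay, the position on the six-membered aromatic ring of carbon only, para to a large group, proves sensitive to the group it carries: 1H-imidazol-1-yl in place of tert-butyl gives a number 19.6 percentage points lower from compound 2 to compound 3 (beyond the scatter). For the compounds shown here, this is the first step that stands clear of the scatter. Nothing at hand accounts for the fall.

Going by these compounds, whether a dimethylamino group or a carboxylic acid at this position would keep or lose the number of compound 2 stays open. So does whether the same change would count equally on the scaffold of compound 1.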